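A fluoro for methoxy swap under an assay limit

The compounds below may be only part of what the source reports. "The series", "measured", "known", "first", "only" and "open" are said of these compounds alone.

In a functional assay on L1210 cells (Mus musculus) for antiproliferative activity, read by MTT assay (a lower number here means a stronger inhibitor, a higher number a weaker inhibitor), compound 3 (`COc1ccc(/C=N/NC(=O)c2cn(C3CC3)c3cc(N4CCNCC4)c(F)cc3c2=O)cc1`) gives <= 25000 nM as a limit, not a number. Compound 2 (`O=C(N/N=C/c1ccccc1O)c1cn(C2CC2)c2cc(N3CCNCC3)c(F)cc2c1=O`) gives <= 25000 nM as a limit too. Compound 1 (`O=C(N/N=C/c1ccc(F)cc1)c1cn(C2CC2)c2cc(N/N=C/c3ccc(F)cc3)c(F)cc2c1=O`) gives <= 25000 nM as a limit as well. Compound 3 thus stands with the others, and the limit of <= 25000 nM in this assay, at which 3 of the 3 values shown sit, is all the data offer. Compound 4 (`O=C(N/N=C/c1ccc(F)cc1)c1cn(C2CC2)c2cc(N3CCNCC3)c(F)cc2c1=O`) differs from compound 3 by fluoro in place of methoxy on an aromatic carbon in a change of 4-methoxyphenyl to 4-fluorophenyl. For the measured compounds named here, the one measured step on this group is a step that the two limits leave unreadable from compound 2 to compound 3 and it offers no size to carry over. No change beyond the scatter is therefore expected, and the expected step is a step that the limit leaves unreadable from compound 3 to compound 4 with no favoured direction. For compound 4 the estimate is 15000 nM with an expected range from 3000 nM to 25000 nM at the upper end.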

Compound 4, half-maximal inhibitory concentration: <= 25000 nM
Compound 4: only a limit was reported (the forecaster's own chance of this, stated with the estimate: 70%); the middle value lies beyond the limit too.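

The steps from compound 1, compound 2 and compound 3 to compound 4 cannot be read in this assay because each compound gives only a limit: the limit of <= 25000 nM in this assay, at which 4 of the 4 values shown sit. The compounds shown leave open how strong any of them is and whether fluoro in place of methoxy changes the activity at all.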